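Nitro to Dimethylamino on Monkey Kidney Cell Cytotoxicity

A few compounds are considered here, and "the series" means these few. Any claim that something is new, unique, unknown or untested is made for them only; others in the source may bear on it.

Three compounds were measured in an ADME assay on LLC-MK2 cells (Macaca mulatta) for cytotoxicity, read by MTT assay, with a stated time of 48 h; on this read-out lower numbers stand for higher toxicity in this test and higher numbers for lower toxicity in this test:

Compound 1, `CC(=O)/C(C)=C/c1ccc([N+](=O)[O-])cc1`, gives 266000 nM.
Compound 2, `CC(=O)/C(C)=C/c1ccc(N(C)C)cc1`, gives 150000 nM.
Compound 3, `C/C(=C\c1ccc(N(C)C)cc1)C(=O)/C=C/c1ccc([N+](=O)[O-])cc1`, gives 167000 nM.

Compound 1 and compound 2 differ in one place, (dimethylamino in place of nitro on an aromatic carbon), and the step is a 1.8-fold lower number from compound 1 to compound 2 (0.25 log units; within the scatter). The values of compound 3 and the other two all lie within the scatter of one another. How the core of compound 3 differs from the core of compound 1 is not broken down here. Compound 4, `C/C(=C\c1ccc(N(C)C)cc1)C(=O)/C=C/c1ccc(N(C)C)cc1`, has not been measured; it differs from compound 3 by dimethylamino in place of nitro on an aromatic carbon. Around the place the two cases are described differently: in the first the group sits para to a group of 6 heavy atoms, in the second para to a large group, so the change is the same kind of change, not the same. Because compound 1 and compound 2 show a 1.8-fold lower number from compound 1 to compound 2 (0.25 log units; within the scatter), a step of a 1.7-fold lower number from compound 3 to compound 4 (0.22 log units; within the scatter) is expected. Compound 4 is estimated at 100000 nM, likely between 50000 nM and 250000 nM.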

Compound 4, half-maximal cytotoxic concentration: 314000 nM
Beside the measured number, compound 4's estimate is 3.1-fold (0.50 log units) below it; measured number above the stated range.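

On the core of compound 3, dimethylamino in place of nitro gives a 1.9-fold higher number from compound 3 to compound 4 (0.27 log units; within the scatter) in this assay. Set beside the earlier step, this shows that the change does not carry from one core to the other as a fixed shift: the same change on two cores in this assay, a 1.8-fold lower number (0.25 log units; within the scatter) from compound 1 to compound 2 and a 1.9-fold higher number (0.27 log units; within the scatter) from compound 3 to compound 4, 3.3-fold (0.52 log units) apart, beyond the scatter of two such steps. The comparison rests on a single pair per core, with each step within the scatter on its own, and it does not show which feature of the cores sets the two steps apart.

The compounds shown leave open whether the gap between the cores would also appear with other groups in this place, such as methoxy, chlorine or a carboxylic acid. They also leave open how the core of compound 3 would stand with two nitro groups.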